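Phenyl in Place of Cyclohexyl at the Ring Nitrogen

The source may hold more compounds than are shown below. What is called first, only, known or untested is meant among the compounds shown, and "the series" means these compounds.

Of the compounds shown here, three built on a shared core have been measured in a functional assay on A-375 cells (Homo sapiens) for antiproliferative activity, read by CCK-8 assay, with a stated time of 72 h, tested at 8 uM; a higher number here means a stronger effect of the compound at the concentration tested, a lower number a weaker effect. Compound 1 `Nc1ccccc1NC(=O)c1ccc(CSC(=S)N2CCN(C3CCCCC3)CC2)cc1` gives 89.9%. Compound 2 `CC1CCCCN1C(=S)SCc1ccc(C(=O)Nc2ccccc2N)cc1` gives 85.2%, and compound 3 `CN(Cc1cccnc1)C(=S)SCc1ccc(C(=O)Nc2ccccc2N)cc1` gives 83.8%. Compound 1 has the highest of the three numbers, but its gaps to compound 2 and to compound 3 both lie within the scatter, so the three stand level rather than in any order. Among the compounds with values here, the single step between compounds that differ in one place, a number 1.4 percentage points lower from compound 2 to compound 3 (within the scatter), is likewise within the scatter; it exchanges groups on the thiocarbonyl carbon, not at the position that changes here.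

Compound 4 `Nc1ccccc1NC(=O)c1ccc(CSC(=S)N2CCN(c3ccccc3)CC2)cc1` differs from compound 1 by phenyl in place of cyclohexyl on an amine nitrogen in a ring. Within the data shown here, no measured step bears directly on this position, and the one step that exists, at the thiocarbonyl carbon, was flat. The three measured values sit close together at a high level, which gives no ground to expect a shift. The step of a number 4.9 percentage points lower from compound 1 to compound 4 (within the scatter) is therefore expected to stay within the scatter, in no clear direction. In this assay compound 4 is estimated at 85%, with a range from 72% to 95%.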

Compound 4, a percentage reported as inhibition, at one concentration (the size of the read-out at that concentration, not a potency): 88.6%
The estimate for compound 4 lay 3.6 percentage points below the measured number; the range from low to high includes it.
By their numbers in this assay, from the lowest: compounds 3, 2, 4 and 1 (each within the scatter of the next).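

Within the data shown here, this is the first measured step at this position: in this assay, phenyl in place of cyclohexyl on an amine nitrogen in a ring gives a number 1.3 percentage points lower from compound 1 to compound 4 (within the scatter). The two groups have the same count of heavy atoms and neither has a hydrogen-bond donor or acceptor, so the exchange of a non-aromatic carbon ring for an aromatic one is a clean comparison, and it leaves compound 1 and compound 4 level. Among these compounds, at the one concentration tested, the read-out therefore does not separate these two rings at this nitrogen, and the earlier compounds, which had only a step on the thiocarbonyl carbon, could not show this. No evidence is available to explain why the two rings stand level.

The compounds shown leave open whether a group other than a six-membered carbon ring at this nitrogen, such as a methyl, an acetyl or a short chain ending in a carboxylic acid, would stay at the same level. All four numbers lie within the scatter of the next at a single concentration, so they also leave open whether cyclohexyl and phenyl would differ in potency.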